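Swapping Methyl for Methylsulfanyl in Compound 3

This account rests on a few compounds, and the source may have more. Where it says the series, first, only, none or still open, it means among the compounds named here.

Compound 2 `Cc1cc(C(F)(F)F)ccc1C(=O)NC1(c2ccccc2)CCCN(C)C1` stands lowest of the two numbers measured in an assay on cells for inhibition of sodium- and chloride-dependent glycine transporter 1 (Homo sapiens) (a lower number here means that less compound is needed, a higher number that more compound is needed for the effect), where compound 2 gives 320 nM. Compound 1 `CN1CCCC(NC(=O)c2ccc(C(F)(F)F)cc2F)(c2ccccc2)C1` gives 9900 nM in this assay. Compound 3 `CSc1cc(C(F)(F)F)ccc1C(=O)NC1(c2ccccc2)CCCN(C)C1` differs from compound 2 by methylsulfanyl in place of methyl on an aromatic carbon. Among the compounds with values here, the only measured step, a 31-fold lower number from compound 1 to compound 2 (1.49 log units; beyond the scatter), changed the group on this same aromatic carbon, so the spot matters, yet no measured step involves methylsulfanyl itself. A small step in either direction, or none beyond the scatter, is therefore expected. Compound 3 is estimated at 250 nM, between 70 nM and 900 nM, which would mean a 1.3-fold lower number from compound 2 to compound 3 (0.11 log units; within the scatter).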

Compound 3, half-maximal effective concentration: 67 nM
Beside the measured number, compound 3's estimate is 3.7-fold (0.57 log units) above it, and the stated range ends above it.
By their numbers in this assay, from the lowest: compound 3; then compound 2; then compound 1.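

In this assay, methylsulfanyl on this aromatic carbon gives a 4.8-fold lower number from compound 2 to compound 3 (0.68 log units; beyond the scatter), so methyl does not set the lowest number here, and a group holding a sulfur atom is accepted at this place. The contrast with fluoro is much wider, at a 150-fold lower number from compound 1 to compound 3 (2.17 log units; beyond the scatter), so across these three groups, changing this one place alone moves the number a long way. Nothing measured here explains why these groups rank in this order.

The compounds shown leave open how a methoxy group, or a longer chain such as ethylsulfanyl, would fare on this same carbon.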